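A few compounds are considered here, and "the series" means these few. Any claim that something is new, unique, unknown or untested is made for them only; others in the source may bear on it.

Measured so far in the series:

compound 1, `O=S(=O)(NCc1csc2ccccc12)c1ccc(C(F)(F)F)cc1`: 94800 nM
compound 2, `Cc1ccc(S(=O)(=O)NCc2csc3ccccc23)cc1`: > 210000 nM
compound 3, `O=S(=O)(NCc1cc2ccccc2s1)c1ccc(C(F)(F)F)cc1`: > 179000 nM

Among the measured compounds shown here, in an ADME assay on MDCK cells (Canis lupus familiaris) for cytotoxicity, read by MTT assay, with a stated time of 24 h (a higher number here means that more compound is tolerated, a lower number that less compound is tolerated), compound 1 gives 94800 nM and is the only compound of the three with a numerical value. For compound 2 the reading is a limit of the assay, > 210000 nM, not a number. For compound 3 the reading is likewise a limit, > 179000 nM. For the measured compounds named here, the one counted step among the measured compounds, (methyl in place of trifluoromethyl on an aromatic carbon), gives an at least 2.2-fold higher number from compound 1 to compound 2 (0.34 log units; beyond the scatter). The limit of > 210000 nM in this assay, at which 1 of the 3 values shown sits, is where compound 2 sits, so the true size of that step is open upward.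

Compound 3 and compound 1 are built from the same atoms joined differently; the difference between the two cores is not broken down here.

Compound 4, `Cc1ccc(S(=O)(=O)NCc2cc3ccccc3s2)cc1`, is not yet measured. It stands to compound 3 as compound 2 stands to compound 1: methyl in place of trifluoromethyl on an aromatic carbon. The place of the change reads the same in both pairs, so this is the same change. Compound 3 already sits at the limit (the limit of > 179000 nM in this assay, at which 1 of the 3 values shown sits), and the step from compound 1 to compound 2 moved toward the tolerated side, so for compound 4 the expected outcome is a reading at or beyond the top of the assay, a step that the limit leaves unreadable from compound 3 to compound 4, as an estimate. Compound 4 is therefore expected near 260000 nM, within 150000 nM to 500000 nM, with a high chance that only a limit is reported.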

Compound 4, half-maximal cytotoxic concentration: > 210000 nM
Compound 4 gave a limit, no number; the forecaster's own chance of this, stated with the estimate: 80%; the middle value lies beyond the limit too.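

In this assay compound 4 gives > 210000 nM, a limit and not a number. Among the compounds shown here, compound 3 likewise gives a limit, > 179000 nM, so no step between compound 3 and compound 4 can be read. The compounds shown leave open where the true values of these two lie, and so whether methyl in place of trifluoromethyl has the same size of effect on both cores.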